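A few compounds are considered here, and "the series" means these few. Any claim that something is new, unique, unknown or untested is made for them only; others in the source may bear on it.

Measured compounds:
Compound 1, `c1ccc(-c2noc(Cc3c[nH]c4ccccc34)n2)cc1`. In a functional assay on cells (Splenocyte, Mus musculus, strain BALB/c) for inhibition, read by scintillation counting and thymidine incorporation, with stated times of 48 h and 8 h (a higher number here means a weaker inhibitor, a lower number a stronger inhibitor), compound 1 gives > 50000 nM, which is a limit of the assay rather than a number.
Compound 2, `COc1cc(-c2nc(Cc3c[nH]c4ccccc34)no2)cc(OC)c1OC`. In this assay compound 2 gives 3100 nM.

Among the compounds with values here, compound 2 holds the only actual number in this assay; the other value shown is the limit, (the limit of > 50000 nM in this assay, at which 1 of the 2 values shown sits). The next compound, compound 3, `COc1cc(OC)cc(-c2nc(Cc3c[nH]c4ccccc34)no2)c1`, differs from compound 2 in one place: hydrogen in place of methoxy on an aromatic carbon. Within the data shown here, no step between two measured compounds is available here, so the expectation rests on the two values alone. Compound 1, with no methoxy on that ring, stays at the limit, while compound 2 with its methoxy groups gives a number. Taking one methoxy away moves compound 3 toward compound 1, so a weaker result than compound 2 is expected, and the step from compound 2 to compound 3 is estimated as a 3.9-fold higher number from compound 2 to compound 3 (0.59 log units; beyond the scatter), beyond the scatter. Compound 3 is expected to give about 12000 nM, between 3000 nM and 50000 nM.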

Compound 3, half-maximal inhibitory concentration: 13900 nM
The estimate for compound 3 lay 1.2-fold (0.06 log units) below the measured number, and the stated range covers the measured number.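

In this assay, hydrogen in place of the methoxy that sits para to a large group and ortho to two methoxy groups gives a 4.5-fold higher number from compound 2 to compound 3 (0.65 log units; beyond the scatter) and so shows that this one group counts on its own. With two methoxy groups left on the ring, compound 3 still gives 13900 nM and not a limit of the assay. Within the data shown here, compound 1 differs from compound 3 in more than one place, so no step to it can be read, and its value remains a limit: the limit of > 50000 nM in this assay, at which 1 of the 3 values shown sits.

Whether the methoxy itself is needed at this position stays open, since a hydroxyl, a fluorine or an ethoxy there lies outside the compounds shown. Also open, going by these compounds, is what taking away either of the other two methoxy groups would do, with the remaining group left in place.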